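The compounds below may be only part of what the source reports. "The series", "measured", "known", "first", "only" and "open" are said of these compounds alone.

Compound 1 `CCC(CC)(c1nnc[nH]1)c1ccc(-c2ccc3cc(F)cc(F)c3c2)[nH]c1=O` gives 89 nM.
Compound 2 `CC(C)C(Cc1nnc[nH]1)c1ccc(-c2ccc3cccc(F)c3c2)[nH]c1=O` gives 10 nM.
Compound 3 `CCn1ncc2c(F)cc(-c3ccc(C(CC)(CC)c4nncn4C)c(=O)[nH]3)cc21` gives 54 nM.

All three numbers come from an assay on CHO cells for displacement of a labelled ligand from prostaglandin E2 receptor EP3 subtype (Homo sapiens), read by radioligand binding; on this read-out higher numbers stand for weaker inhibition and lower numbers for stronger inhibition. Among them compound 2 has the lowest number: compound 3 stands at a higher number, a gap beyond the usual scatter, and compound 1 is further away still, also beyond the scatter. Compound 4 `CC(C)C(/C=C1/CCNC1=O)c1ccc(-c2ccc3cccc(F)c3c2)[nH]c1=O` has not yet been measured in this assay. It differs from compound 2 in a single place: a group of 7 heavy atoms (5 carbon, 1 nitrogen, 1 oxygen; one five-membered non-aromatic ring with 1 hetero atom) in place of a group of 6 heavy atoms (3 carbon, 3 nitrogen; one five-membered aromatic ring with 3 hetero atoms), on a saturated chain carbon bound to an aromatic carbon and a saturated chain carbon. No measured pair among these compounds shows what a swap of this kind does, so the expectation for compound 4 has to rest on the value of compound 2 alone, with wide uncertainty. Because compound 2 gives 10 nM and the group that leaves is replaced by one of a quite different make-up, the number for compound 4 is expected to rise by a step of a 4.0-fold higher number from compound 2 to compound 4 (0.60 log units; beyond the scatter), that is toward weaker inhibition, beyond the scatter. Compound 4 is therefore estimated at 40 nM in this assay, within a range from 10 nM to 200 nM.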

Compound 4, inhibition constant: 5.3 nM
Compound 4: the middle estimate sits 7.5-fold (0.88 log units) above what was measured, outside the stated range (below it).
By their numbers in this assay, from the lowest: compounds 4 and 2 (each within the scatter of the next); then compounds 3 and 1 (each within the scatter of the next).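

In this assay, replacing the (4H-1,2,4-triazol-3-yl)methyl group on this saturated chain carbon gives a 1.9-fold lower number from compound 2 to compound 4 (0.28 log units; within the scatter), so the two compounds cannot be told apart on this read-out. At this position, then, binding in this assay does not depend on keeping the five-membered aromatic ring with its three nitrogens: a group built on a five-membered non-aromatic ring with one hetero atom serves as well. Nothing available here accounts for this match.

Going by these compounds, it remains open whether a carboxylic acid, an amine or a plain ethyl chain in this place would keep the number in this range. A single pair also cannot show whether the same swap would hold up on the different cores of compound 1 and compound 3.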